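A few compounds are considered here, and "the series" means these few. Any claim that something is new, unique, unknown or untested is made for them only; others in the source may bear on it.

In an assay on RKO cells for inhibition of ubiquitin carboxyl-terminal hydrolase 7 (Homo sapiens), read by a luciferase reporter, with a stated time of 18 h (a higher number here means that more compound is needed for the effect, a lower number that less compound is needed), three compounds have been measured:

Compound 1 `Cc1cc(Cl)cc(-c2ccnc3cc(CN4C(=O)C5C(C4=O)C5(C)C)sc23)c1C[C@@H]1CNCCO1` gives 25 nM.
Compound 2 `Cc1cc(Cl)cc(-c2ccnc3cc(CN4C(=O)C5CC5C4=O)sc23)c1C[C@@H]1CNC[C@@H](C)O1` gives 60 nM.
Compound 3 `Cc1cc(Cl)cc(-c2ccnc3cc(CN4C(=O)C5CC5C4=O)sc23)c1C[C@@H]1CNCCO1` gives 35 nM.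

Compound 3 holds the second highest of these three numbers, and both gaps that surround it, a 1.4-fold higher number from compound 1 to compound 3 (0.15 log units; within the scatter) and a 1.7-fold lower number from compound 2 to compound 3 (0.23 log units; within the scatter), lie within the scatter, so the three compounds cannot be told apart on these numbers.

Compound 4 `Cc1cc(Cl)cc(-c2ccnc3cc(CN4C(=O)C5CC5C4=O)sc23)c1O[C@@H]1CCNC[C@@H]1C` differs from compound 3 in one place: (3-methylpiperidin-4-yl)oxy in place of (morpholin-2-yl)methyl on an aromatic carbon. Neither measured step bears directly on this change. One altered the group on the saturated chain carbon at the other end of the molecule, the other only removed a methyl from the ring that now leaves, and both stayed within the scatter. For the measured compounds named here, with no guiding step, compound 4 is expected to show a 1.7-fold higher number from compound 3 to compound 4 (0.23 log units; within the scatter) in this assay, that is, no change beyond the scatter. The estimate for compound 4 is 60 nM, with a range from 20 nM to 200 nM.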

Compound 4, half-maximal effective concentration: 170 nM
Estimate against measurement, compound 4: 2.8-fold (0.45 log units) below; low and high end bracket the measured number.
By their numbers in this assay, from the lowest: compounds 1, 3 and 2 (each within the scatter of the next, the first and the last beyond it); then compound 4.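

Unlike the earlier steps, this change at the aromatic carbon moves the number beyond the scatter: a 4.9-fold higher number from compound 3 to compound 4 (0.69 log units; beyond the scatter) when (3-methylpiperidin-4-yl)oxy replaces (morpholin-2-yl)methyl. The same entering group gives a 2.8-fold higher number from compound 2 to compound 4 (0.45 log units; beyond the scatter) when it replaces (6-methylmorpholin-2-yl)methyl, so the rise appears against both morpholine groups. Nothing measured here explains this rise.

The swap alters both the ring and the link to the aromatic carbon, and the compounds shown do not separate these two changes. A (morpholin-2-yl)oxy or (3-methylpiperidin-4-yl)methyl group at this place would address that.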